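Cytotoxicity of two analogs and a cyanoethyl variant

This account rests on a few compounds, and the source may have more. Where it says the series, first, only, none or still open, it means among the compounds named here.

Measured so far:
compound 1, `Cc1cc(C#N)cc(C)c1Oc1cc(Nc2ccc(C#N)cc2)c(N)cc1COC(C)C`: 89400 nM
compound 2, `CC(=O)OCc1cc(N)c(Nc2ccc(C#N)cc2)cc1Oc1c(C)cc(C#N)cc1C`: 113000 nM

Within the data shown here, in an ADME assay on MT2 cells (Homo sapiens) for cytotoxicity (on this read-out lower numbers stand for higher toxicity in this test and higher numbers for lower toxicity in this test), compound 2 holds the highest of the two numbers, and the only other compound, compound 1, lies within the scatter of it, as a 1.3-fold higher number from compound 1 to compound 2 (0.10 log units; within the scatter) shows. Compound 3, `CC(=O)OCc1cc(N)c(Nc2ccc(C#N)cc2)cc1Oc1c(C)cc(CCC#N)cc1C`, differs from compound 2 by 2-cyanoethyl in place of cyano on an aromatic carbon. Among the measured compounds shown here, no measured step changes that position; the single measured step concerns another part of the molecule, so it gives no direct guide. Without such a guide, a step no larger than the scatter is expected, a 1.0-fold lower number from compound 2 to compound 3 (0.01 log units; within the scatter), and compound 3 is estimated at 110000 nM, ranging from 50000 nM to 240000 nM.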

Compound 3, half-maximal cytotoxic concentration: 44800 nM
Compound 3: middle estimate off by 2.5-fold (0.39 log units), on the high side; measured number below the stated range.
By their numbers in this assay, from the lowest: compounds 3, 1 and 2 (each within the scatter of the next, the first and the last beyond it).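

This position on the ring carrying the two methyl groups is not silent in this assay: 2-cyanoethyl in place of cyano gives a 2.5-fold lower number from compound 2 to compound 3 (0.40 log units; beyond the scatter), which here means higher toxicity in this test. The earlier step, at another part of the molecule, stayed within the scatter, with a 1.3-fold higher number from compound 1 to compound 2 (0.10 log units; within the scatter). Nothing available accounts for this shift.

From the compounds shown here alone, what a longer chain or an amine in this place would give remains open. So does whether the same change would have a similar effect with the isopropyl group of compound 1.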